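Working notes: from compound 2 toward compound 3

The compounds below may be only part of what the source reports. "The series", "measured", "known", "first", "only" and "open" are said of these compounds alone.

Compound 1 `Cc1nnc(SCC(=O)Nc2ccc(-c3nc(-c4ccccc4)c(-c4ccccc4)n3C)cc2)s1` and compound 2 `CN1CCN(CC(=O)Nc2ccc(-c3nc(-c4ccccc4)c(-c4ccccc4)n3C)cc2)CC1` share one core and differ only in the group on the saturated chain carbon bound to the carbonyl carbon. In a functional assay on MCF7 cells (Homo sapiens) for cytotoxicity, read by MTT assay, with a stated time of 24 h, tested at 16 ug/mL (a higher number here means a stronger effect of the compound at the concentration tested, a lower number a weaker effect), compound 1 gives 74.9%, while compound 2 gives 30.1%. For the measured compounds named here, compound 2 thus stands lowest of the two numbers; its only neighbour is compound 1, and the step of a number 44.8 percentage points lower from compound 1 to compound 2 (beyond the scatter) lies clearly beyond the scatter.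

Compound 3 `Cn1c(-c2ccc(NC(=O)CN3CCN(Cc4ccc(Cl)cc4)CC3)cc2)nc(-c2ccccc2)c1-c1ccccc1` is not yet measured. It differs from compound 2 as follows: 4-chlorophenyl in place of hydrogen on a saturated chain carbon bound to an amine nitrogen in a ring. Going by the values given here, the one measured step concerns a different place, the chain carbon bound to the carbonyl carbon, and exchanges the whole chain end rather than adding to it; it shows that this region moves the read-out strongly but offers no direction for growth on the amine nitrogen in a ring. Among the compounds with values here, no measured pair mirrors the present change. The expectation for compound 3 is therefore a small rise, a number 9.9 percentage points higher from compound 2 to compound 3 (within the scatter), with wide uncertainty. Compound 3 is estimated at 40%, within 20% to 65%.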

Compound 3, a percentage reported as activity, at one concentration (the size of the read-out at that concentration, not a potency): 46.2%
The estimate for compound 3 lay 6.2 percentage points below the measured number; low and high end bracket the measured number.
By their numbers in this assay, from the lowest: compound 2; then compound 3; then compound 1.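

In this assay, the amine nitrogen in a ring proves to be a place where growth changes the read-out: exchanging methyl for 4-chlorobenzyl, that is, 4-chlorophenyl in place of hydrogen on a saturated chain carbon bound to an amine nitrogen in a ring, gives a number 16.1 percentage points higher from compound 2 to compound 3 (beyond the scatter) and is a modest step. The earlier pair showed only what happens when the whole chain end is exchanged, whereas this step keeps that chain end and extends it, so the read-out can be raised without leaving the amine series. No measurement bears on why the added group raises the number.

The compounds shown leave open whether the step belongs to the chlorine or to the aromatic ring itself, a question that a plain benzyl or a 4-methoxybenzyl group on the same nitrogen would address. For the compounds shown here, also open is whether a longer chain carrying the 4-chlorophenyl would extend the step further or lose it, since only one group at this place can be compared with methyl.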